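The source may report more compounds than this note shows. Statements on the series, on what has been measured and on what is new or still open speak of the compounds shown alone.

Measured so far:

- compound 1, `COc1cc(OC)c(C(=O)/C=C/c2ccc(Br)cc2)c(OC)c1`: 7100 nM
- compound 2, `COc1cccc(/C=C/C(=O)c2c(O)cc(OC)cc2OC)c1`: 7300 nM
- compound 3, `COc1cc(O)c(C(=O)/C=C/c2ccccc2SC)c(OC)c1`: 8700 nM

All three were tested in a functional assay on PC-3 cells (Homo sapiens) for cytotoxicity, with a stated time of 48 h; on this read-out lower numbers stand for stronger inhibition and higher numbers for weaker inhibition. Compound 1 gives the lowest of the three numbers, yet compound 2 and compound 3 both lie within the usual scatter of it, so the three compounds cannot be told apart on these values; none is stronger or weaker than another. The core of compound 1 carries three methoxy groups on one ring and a bromo group on the other.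

Compound 4, `COc1cc(OC)c(C(=O)/C=C/c2ccc(F)cc2)c(OC)c1`, has not yet been measured in this assay. It differs from compound 1 in one place only:

fluoro in place of bromo on an aromatic carbon

Among the compounds with values here, no measured pair in this set shows a bromo-to-fluoro exchange, so there is no directly comparable step to lean on. Since compound 1 shows 7100 nM, a modest shift toward a higher number is expected, with a change from compound 1 to compound 4 of about a 1.5-fold higher number from compound 1 to compound 4 (0.19 log units; within the scatter). For compound 4 the estimate is 11000 nM, in the range 4500 nM to 30000 nM.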

Compound 4, half-maximal inhibitory concentration: 5500 nM
Beside the measured number, compound 4's estimate is 2.0-fold (0.30 log units) above it; measured number inside the range.
By their numbers in this assay, from the lowest: compounds 4, 1, 2 and 3 (each within the scatter of the next).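

Within the data shown here, this is the first direct comparison at this position of the shared core. In this assay, replacing the 4-bromophenyl with a 4-fluorophenyl gives a 1.3-fold lower number from compound 1 to compound 4 (0.11 log units; within the scatter), so the two compounds cannot be told apart, and on this single pair either halogen can sit on the aromatic carbon para to a large group without a readable difference. No measurement is available here that would help interpret this result.

Going by these compounds, both groups at this position are halogens, so it remains open whether the position matters at all or would respond to a very different group, such as an amine, a carboxylic acid or a longer chain. On these data alone, whether the same exchange would also read as it does here on a differently substituted core also remains unknown.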